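Chloro to methyl on a chromone core: cytotoxicity in MCF7 cells

The source may hold more compounds than are shown below. What is called first, only, known or untested is meant among the compounds shown, and "the series" means these compounds.

Measured compounds:
compound 1 `Cc1cc(C)nc(SCc2cc(=O)c3cc(Cl)ccc3o2)n1`: > 25000 nM
compound 2 `O=c1cc(CSc2nc3ccccc3s2)oc2ccc(Cl)cc12`: > 25000 nM
compound 3 `Cc1ccc2oc(CSc3nc(C)cc(C)n3)cc(=O)c2c1`: > 25000 nM

Of the compounds shown here, three have been tested in a functional assay on MCF7 cells (Homo sapiens) for cytotoxicity, read by MTT assay, with a stated time of 72 h; on this read-out lower numbers stand for stronger inhibition and higher numbers for weaker inhibition. In this assay compound 1 `Cc1cc(C)nc(SCc2cc(=O)c3cc(Cl)ccc3o2)n1` reaches only the limit > 25000 nM, which is a bound of the assay and not a number. Compound 2 `O=c1cc(CSc2nc3ccccc3s2)oc2ccc(Cl)cc12` likewise gives only the limit > 25000 nM. Compound 3 `Cc1ccc2oc(CSc3nc(C)cc(C)n3)cc(=O)c2c1` also stops at the limit > 25000 nM. All three values therefore sit at the limit of > 25000 nM in this assay, at which 3 of the 3 values shown sit.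

Compound 3 differs from compound 1 by one change, (methyl in place of chloro on an aromatic carbon), and the step that the two limits leave unreadable from compound 1 to compound 3 cannot be read, since both ends are limits. The difference between the core of compound 1 and the core of compound 2 is not broken down here.

Compound 4 `Cc1ccc2oc(CSc3nc4ccccc4s3)cc(=O)c2c1`, not yet measured, stands to compound 2 as compound 3 stands to compound 1: the change is methyl in place of chloro on an aromatic carbon, the same change at the same place. Going by the values given here, because compound 1 and compound 3 both sit at the limit of > 25000 nM in this assay, at which 3 of the 3 values shown sit, no direction for the step can be inferred, and compound 2 itself lies at the limit.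

On this basis compound 4 is expected to remain at the limit as well, with an estimated step that the limit leaves unreadable from compound 2 to compound 4 from compound 2. The value estimated for compound 4 is 30000 nM, expected to lie between 10000 nM and 100000 nM.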

Compound 4, half-maximal inhibitory concentration: > 25000 nM
Compound 4 was reported as a limit; the forecaster's own chance of this, stated with the estimate: 85%; the middle value is on the limit's open side.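

In this assay compound 4 gives > 25000 nM as a limit and not a number. Going by these compounds alone, no step from compound 2 to compound 4 can be read, since both compounds stop at a limit: the limit of > 25000 nM in this assay, at which 4 of the 4 values shown sit.

The compounds shown leave open whether methyl in place of chloro on an aromatic carbon changes cytotoxicity at all, as none of them gives a number.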